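The source may hold more compounds than are shown below. What is called first, only, known or untested is meant among the compounds shown, and "the series" means these compounds.

Working notes on the series.

Compound 1 `CCCCc1c(C)c(OC)c2ccccc2c1OC(C)=O` gives 200 nM in a functional assay for inhibition, with Rattus norvegicus as the target; a lower number here means a stronger inhibitor, a higher number a weaker inhibitor. Compound 2 `CCCCc1cc(OC)c2ccccc2c1OC(C)=O` gives 440 nM in this assay. The two differ by one change, (methyl in place of hydrogen on an aromatic carbon), and the step of a 2.2-fold lower number from compound 2 to compound 1 (0.34 log units; beyond the scatter) describes what it did. Compound 3 `CCc1c(CC)c(OC(C)=O)c2c(C)c(C)cc(C)c2c1OC` gives 15700 nM in this assay; the difference between its core and the core of compound 2 is not broken down here, and the two values simply show compound 3 well above compound 2.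

Compound 4 `CCc1c(CC)c(OC(C)=O)c2c(C)c(C)c(C)c(C)c2c1OC` has not been measured. It differs from compound 3 by methyl in place of hydrogen on an aromatic carbon. This is the same kind of change as from compound 2 to compound 1, not the same: there the place was ortho to a butyl group and to a methoxy group and meta to an acetoxy group, here it is ortho to two methyl groups and meta to a methyl group. Among the measured compounds shown here, with only one earlier step of this kind to rest on, a modest lowering of the number is expected for compound 4, about a 1.7-fold lower number from compound 3 to compound 4 (0.24 log units; within the scatter), set beside the earlier 2.2-fold lower number from compound 2 to compound 1 (0.34 log units; beyond the scatter). The estimate for compound 4 in this assay is 9000 nM, between 4000 nM and 25000 nM.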

Compound 4, half-maximal inhibitory concentration: 37300 nM
Beside the measured number, compound 4's estimate is 4.1-fold (0.62 log units) below it; the whole stated range lies below it.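

Adding a methyl on an aromatic carbon of the core of compound 3 gives a 2.4-fold higher number from compound 3 to compound 4 (0.38 log units; beyond the scatter) in this assay, whereas the same kind of change on the core of compound 2 lowered the number. The direction of this change therefore does not carry from one core to the other among the compounds shown, and the two steps are truly different rather than scatter around one shared effect: the same change on two cores in this assay, a 2.2-fold lower number (0.34 log units; beyond the scatter) from compound 2 to compound 1 and a 2.4-fold higher number (0.38 log units; beyond the scatter) from compound 3 to compound 4, 5.2-fold (0.72 log units) apart, beyond the scatter of two such steps

Which difference between the two cores or the two places sets the direction is not shown, and two steps give no rule for any further core.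

Open, on these data alone, is whether an amine, a carboxylic acid or a propyl chain in place of the new methyl would move the number on the core of compound 3 the same way as the methyl does. Also open, as far as these compounds go, is whether the upward step holds for a methyl at other aromatic carbons of that core, or is confined to the place it occupies in compound 4.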